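The source may report more compounds than this note shows. Statements on the series, on what has been measured and on what is new or still open speak of the compounds shown alone.

Compound 1 `Cc1ccc(-c2nn(-c3ccccc3)cc2CNc2ccc(Br)cc2)cc1` in an ADME assay on BHK-21 cells (Mesocricetus auratus) for cytotoxicity, read by MTT assay, with a stated time of 72 h (a lower number here means that less compound is tolerated, a higher number that more compound is tolerated), gives only a limit, > 100000 nM. Compound 2 `Cc1ccc(-c2nn(-c3ccccc3)cc2CNc2ccc(C(F)(F)F)cc2)cc1` carries trifluoromethyl in place of bromo on an aromatic carbon and gives 88000 nM in this assay; the step is an at least 1.1-fold lower number from compound 1 to compound 2 (0.05 log units; that floor lies within the scatter). Compound 3 `Brc1ccc(NCc2cn(-c3ccccc3)nc2-c2ccc(Br)cc2)cc1` likewise gives only a limit, > 100000 nM, in this assay. The core of compound 3 differs from the core of compound 1 by bromo in place of methyl on an aromatic carbon, and the step that the two limits leave unreadable from compound 1 to compound 3 cannot be read because of the limit of > 100000 nM in this assay, at which 2 of the 3 values shown sit. Compound 4 `FC(F)(F)c1ccc(-c2nn(-c3ccccc3)cc2CNc2ccc(Br)cc2)cc1`, not yet measured, carries the same change that separates compound 2 from compound 1: trifluoromethyl in place of bromo on an aromatic carbon. Resting on an at least 1.1-fold lower number from compound 1 to compound 2 (0.05 log units; that floor lies within the scatter), the expected step is an at least 1.1-fold lower number from compound 3 to compound 4 (0.04 log units; that floor lies within the scatter), which may again leave only a limit. For compound 4 in this assay the expected value is 90000 nM, with a range from 45000 nM to 180000 nM.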

Compound 4, half-maximal cytotoxic concentration: 28000 nM
The estimate for compound 4 lay 3.2-fold (0.51 log units) above the measured number, outside the stated range (below it).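

In this assay, trifluoromethyl in place of bromo on an aromatic carbon gives an at least 3.5-fold lower number from compound 3 to compound 4 (0.55 log units; beyond the scatter), and trifluoromethyl in place of methyl gives an at least 3.5-fold lower number from compound 1 to compound 4 (0.55 log units; beyond the scatter). Set beside the earlier step, the same change on the two cores reads: the same change on two cores in this assay, an at least 1.1-fold lower number (0.05 log units; that floor lies within the scatter) from compound 1 to compound 2 and an at least 3.5-fold lower number (0.55 log units; beyond the scatter) from compound 3 to compound 4; the limit leaves it open whether they differ. The floor on the core of compound 3 lies beyond the scatter and the other floor does not, yet this gives no size that can be carried from one core to another, as both steps start from limits: the limit of > 100000 nM in this assay, at which 2 of the 4 values shown sit.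

Still open, from the compounds shown here alone, is how this assay would read with an amine or a carboxylic acid in place of the bromo or trifluoromethyl group. Going by these compounds, the values of compound 1 and compound 3 also remain unknown beyond their limits.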